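The source may hold more compounds than are shown below. What is called first, only, known or untested is meant among the compounds shown, and "the series" means these compounds.

Measured so far in a functional assay on HeLa cells (Homo sapiens) for inhibition, read by MTT assay, with a stated time of 72 h; on this read-out lower numbers stand for stronger inhibition and higher numbers for weaker inhibition:
compound 1 `COc1ccc(-c2nnc(SCCCN3CCN(c4nc5ccccc5o4)CC3)o2)cc1`: 210000 nM
compound 2 `Clc1ccc(-c2nnc(SCCCN3CCN(c4nc5ccccc5o4)CC3)o2)cc1`: 101000 nM
compound 3 `COc1ccc(-c2nnc(SCCCN3CCN(c4nc5ccccc5s4)CC3)o2)cc1`: 165000 nM

Compound 3 gives 165000 nM, which lies within the usual scatter of both compound 1 and compound 2, so it has no clearly separate place among the three. The next compound is compound 4 `CC(C)(C)Oc1ccc(-c2nnc(SCCCN3CCN(c4nc5ccccc5s4)CC3)o2)cc1`, which differs from compound 3 as follows: tert-butyl in place of methyl on an oxygen on an aromatic ring. This is methoxy to tert-butoxy.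

Going by the values given here, no measured step alters the group on that oxygen while keeping the oxygen. The nearest evidence is a 2.1-fold lower number from compound 1 to compound 2 (0.32 log units; beyond the scatter), where the methoxy group itself is replaced. The other measured step, a 1.3-fold lower number from compound 1 to compound 3 (0.10 log units; within the scatter), leaves the methoxy group untouched and says little about this change. A small step in this assay is therefore expected, leaning towards a lower number and probably not clearly beyond the scatter. The estimated change is a 1.3-fold lower number from compound 3 to compound 4 (0.10 log units; within the scatter). For compound 4 the expected value is 130000 nM, with an estimated range of 60000 nM to 260000 nM.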

Compound 4, half-maximal inhibitory concentration: 217000 nM
Beside the measured number, compound 4's estimate is 1.7-fold (0.22 log units) below it; low and high end bracket the measured number.
By their numbers in this assay, from the lowest: compounds 2, 3, 1 and 4 (each within the scatter of the next, the first and the last beyond it).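

In this assay, going by these compounds alone, the change from methyl to tert-butyl on an oxygen on an aromatic ring gives a 1.3-fold higher number from compound 3 to compound 4 (0.12 log units; within the scatter) and is the first step that alters the group on that oxygen while keeping the oxygen. Three more carbon atoms on this group, with no hydrogen-bond donor or acceptor added, thus bring no clear gain or loss on this read-out. No measured property bears on this step, and no cause can be given for it.

On these data alone, whether a hydroxyl group, an ethoxy group or a longer chain on that oxygen would separate from compound 3 remains open. Also open, as far as these compounds go, is how the tert-butoxy group behaves with a 1,3-benzoxazol-2-yl group on the amine nitrogen in a ring, or how an amine would compare with the chloro of compound 2.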